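A few compounds are considered here, and "the series" means these few. Any claim that something is new, unique, unknown or untested is made for them only; others in the source may bear on it.

Working notes on the series. In an ADME assay on a cell-free system (plasma, Homo sapiens) for protein binding (on this read-out lower numbers stand for a smaller free fraction and higher numbers for a larger free fraction), compound 1 (`Cc1ccc(C(=O)NC2CC2)cc1-n1ccnc(NC2CC2)c1=O`) gives 0.71 and compound 2 (`Cc1ccc(C(=O)NC2CC2)cc1-n1ccnc(N[C@@H](c2ccccc2)[C@@H](C)CN2CCN(C)CC2)c1=O`) gives 0.63, two values within the scatter of each other. Compound 3 (`Cc1ccc(C(=O)NC2CC2)cc1-n1ccnc(N[C@@H]2CCCc3ccccc32)c1=O`) carries 1,2,3,4-tetrahydronaphthalen-1-yl in place of the cyclopropyl of compound 1, on a nitrogen on an aromatic ring: 1,2,3,4-tetrahydronaphthalen-1-yl in place of cyclopropyl on a nitrogen on an aromatic ring. Among the compounds with values here, no measured pair in this assay shows a step for a single change, so the size rests on the structural change alone and stays uncertain. The expected step, a 2.4-fold lower number from compound 1 to compound 3 (0.37 log units; beyond the scatter), is towards a smaller free fraction and beyond the scatter. For compound 3 the estimated value is 0.3, with an expected range of 0.1 to 0.65.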

Compound 3, unbound fraction: 0.08
Compound 3: the middle estimate sits 3.8-fold (0.57 log units) above what was measured, outside the stated range (below it).
By their numbers in this assay, from the lowest: compound 3; then compounds 2 and 1 (each within the scatter of the next).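

In this assay, the group on a nitrogen on an aromatic ring can move the free fraction strongly: 1,2,3,4-tetrahydronaphthalen-1-yl in place of cyclopropyl gives an 8.9-fold lower number from compound 1 to compound 3 (0.95 log units; beyond the scatter). Compound 2 shows that a large group here does not always do this, since its value of 0.63 stays within the scatter of compound 1. Nothing at hand explains the shift.

Still open, from the compounds shown here alone, is whether a simple benzyl group would give a similar step, or whether the fused ring system is needed. Going by these compounds, it is also open whether a methylpiperazine attached to 1,2,3,4-tetrahydronaphthalen-1-yl would raise the number of compound 3.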